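Notes on the series: carboxy replaced by methoxymethyl

The source may hold more compounds than are shown below. What is called first, only, known or untested is meant among the compounds shown, and "the series" means these compounds.

In an ADME assay on microsomes (Homo sapiens) for metabolic stability (a higher number here means faster removal of the compound, a lower number slower removal), compound 1 (`Cc1cc(C(F)(F)F)c2cccc(OCc3c(Cl)ccc(S(=O)(=O)N4CCC[C@H]4C(N)=O)c3Cl)c2n1`) gives 167 mL/min/kg and compound 2 (`Cc1cc(C(F)(F)F)c2cccc(OCc3c(Cl)ccc(S(=O)(=O)N4CCC[C@H]4C(=O)O)c3Cl)c2n1`) gives 8.33 mL/min/kg. Compound 2 therefore holds the lower of the two numbers. Among the compounds with values here, the one measured step is large and beyond the scatter: a 20-fold lower number from compound 1 to compound 2 (1.30 log units; beyond the scatter), with hydroxy in place of amino on a carbonyl carbon.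

Compound 3 (`COC[C@@H]1CCCN1S(=O)(=O)c1ccc(Cl)c(COc2cccc3c(C(F)(F)F)cc(C)nc23)c1Cl`) keeps the shared core and differs from compound 2 as follows: methoxymethyl in place of carboxy on a saturated ring carbon. In short, methoxymethyl stands in place of carboxy on a saturated ring carbon. Within the data shown here, no measured compound carries methoxymethyl, so the evidence is indirect. Among the measured compounds shown here, compound 2 is the only carboxy compound here, and compound 1 without it sits at the high end, as a 20-fold lower number from compound 1 to compound 2 (1.30 log units; beyond the scatter) shows. A large rise is therefore expected, not a step within the scatter: the expected step is a 13-fold higher number from compound 2 to compound 3 (1.12 log units; beyond the scatter). For compound 3 the estimated value is 110 mL/min/kg, with an expected range from 40 mL/min/kg to 230 mL/min/kg.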

Compound 3, clearance: 450 mL/min/kg
The estimate for compound 3 lay 4.1-fold (0.61 log units) below the measured number; measured number outside the range, above it.
By their numbers in this assay, from the lowest: compound 2; then compound 1; then compound 3.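

In this assay, a second group without carboxy on this saturated ring carbon now gives a high number: methoxymethyl in place of carboxy gives a 54-fold higher number from compound 2 to compound 3 (1.73 log units; beyond the scatter) and methoxymethyl in place of carbamoyl gives a 2.7-fold higher number from compound 1 to compound 3 (0.43 log units; beyond the scatter) as a modest further rise. Among these three compounds, the low number therefore stays with carboxy alone, both carbamoyl and methoxymethyl sit well above it, and compound 3 is the highest of the three. Nothing measured here says what lies behind these steps.

The compounds shown leave open whether the low number belongs to the carboxylic acid alone or would also come with a tetrazole or a hydroxymethyl group on this ring carbon. They also leave open whether the same exchange gives a step of this size on a six-membered ring carrying the sulfonyl group.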